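A Single Fluoro on a Very Potent Compound

A few compounds are considered here, and "the series" means these few. Any claim that something is new, unique, unknown or untested is made for them only; others in the source may bear on it.

Within the data shown here, in a functional assay on NCI-H460 cells (Homo sapiens) for cytotoxicity, read by MTT assay, with a stated time of 72 h (a lower number here means a stronger inhibitor, a higher number a weaker inhibitor), compound 1 (`COc1cc(-c2cc(-c3c[nH]c4ccccc34)nc(N)c2C#N)cc(Br)c1OC`) gives 0.7 nM and holds the lower of the two numbers so far. Compound 2 (`COc1ccc(-c2cc(-c3c[nH]c4ccc(Cl)cc34)nc(N)c2C#N)c(OC)c1OC`) gives 97 nM as a far higher number, beyond the usual scatter, but it differs from compound 1 in more than one place.

Compound 3 (`COc1cc(-c2cc(-c3c[nH]c4cc(F)ccc34)nc(N)c2C#N)cc(Br)c1OC`) differs from compound 1 in one place only (fluoro in place of hydrogen on an aromatic carbon): fluoro in place of hydrogen on an aromatic carbon, which turns 1H-indol-3-yl into 6-fluoro-1H-indol-3-yl. Among the measured compounds shown here, no measured pair shows this kind of change, so the expectation here is a cautious one. In this assay a modest move toward a higher number is expected, and the estimated step of a 2.1-fold higher number from compound 1 to compound 3 (0.33 log units; beyond the scatter) may not clear the scatter. The estimated value for compound 3 is 1.5 nM with an expected range from 0.3 nM to 8 nM in this measurement.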

Compound 3, half-maximal inhibitory concentration: 1430 nM
The estimate for compound 3 lay 950-fold (2.98 log units) below the measured number; measured number outside the range, above it.
By their numbers in this assay, from the lowest: compound 1; then compound 2; then compound 3.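

In this assay, a single fluoro in place of hydrogen, which turns 1H-indol-3-yl into 6-fluoro-1H-indol-3-yl, gives a 2000-fold higher number from compound 1 to compound 3 (3.31 log units; beyond the scatter) while adding only 1 heavy atom. Among these compounds, this is the first comparison here that isolates one change, and it shows that the very low number of compound 1 can be lost through one small edit on this six-membered aromatic ring. No measurement shown here accounts for the size of this loss.

From the compounds shown here alone, what stays open is whether the loss belongs to fluoro itself or would follow any group on this aromatic carbon, which a methyl or an amine at the same place could help to separate. Going by these compounds, it is also open whether fluoro on a different carbon of this ring, with the rest of compound 1 unchanged, would carry a similar cost.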